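Estimating the 4-Fluorophenyl Analogue from Two Measured Compounds

The compounds below may be only part of what the source reports. "The series", "measured", "known", "first", "only" and "open" are said of these compounds alone.

Compound 2 `COc1cc(C(=O)N/N=C/c2cc(Cl)cc(Cl)c2)cc(OC)c1OC` stands lowest of the two compounds measured in a functional assay on BGC-823 cells (Homo sapiens) for antiproliferative activity, read by MTT assay, tested at 5 uM (on this read-out lower numbers stand for a weaker effect and higher numbers for a stronger effect at the one concentration tested), where compound 2 gives 9.2% while compound 1 `COc1cc(C(=O)N/N=C/c2ccc(F)c(F)c2)cc(OC)c1OC` gives 51.9%. Compound 3 `COc1cc(C(=O)N/N=C/c2ccc(F)cc2)cc(OC)c1OC` differs from compound 2 by 4-fluorophenyl in place of 3,5-dichlorophenyl on a carbon with a double bond to nitrogen. Among the measured compounds shown here, the only step that bears on this change is a number 42.7 percentage points lower from compound 1 to compound 2 (beyond the scatter), and the change to compound 3 partly reverses that exchange, so a rise beyond the scatter is expected, by about a number 30.8 percentage points higher from compound 2 to compound 3 (beyond the scatter). Compound 3 is therefore estimated at 40%, with a range from 15% to 65%.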

Compound 3, a percentage reported as inhibition, at one concentration (the size of the read-out at that concentration, not a potency): 61.1%
Compound 3: the middle estimate sits 21.1 percentage points below what was measured; the range from low to high includes it.
By their numbers in this assay, from the lowest: compound 2; then compounds 1 and 3 (each within the scatter of the next).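

In this assay, 4-fluorophenyl in place of 3,5-dichlorophenyl on a carbon with a double bond to nitrogen gives a number 51.9 percentage points higher from compound 2 to compound 3 (beyond the scatter), so a single fluoro group is enough to restore a strong read-out here. Hydrogen in place of fluoro on an aromatic carbon gives a number 9.2 percentage points higher from compound 1 to compound 3 (within the scatter), so the second fluoro group of compound 1 makes no difference that can be told from the scatter. Nothing on hand accounts for the low number of compound 2. The compounds shown leave open whether the chlorine atoms themselves or where they sit lower the read-out, and how a phenyl ring carrying an amine or a carboxylic acid would fare on this carbon.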